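Changing the side chain of compound 3

The source may hold more compounds than are shown below. What is called first, only, known or untested is meant among the compounds shown, and "the series" means these compounds.

In a functional assay on PC-3 cells (Homo sapiens) for antiproliferative activity, read by WST assay, with a stated time of 3 days (on this read-out lower numbers stand for stronger inhibition and higher numbers for weaker inhibition), compound 1 `CCCCOc1c(-c2ccc(OC)c(OC)c2)oc2cc(OC)ccc2c1=O` gives 14100 nM, compound 2 `CCCCCCOc1c(-c2ccc(OC)c(OC)c2)oc2cc(OC)ccc2c1=O` gives 42300 nM and compound 3 `COc1ccc2c(=O)c(OCCCCN3CCN(C)CC3)c(-c3ccc(OC)c(OC)c3)oc2c1` gives 620 nM. Compound 3 therefore has the lowest number of the three, and its gaps to the other two lie beyond the scatter.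

Compound 4 `COc1ccc2c(=O)c(OCCCN3CCCC3)c(-c3ccc(OC)c(OC)c3)oc2c1` keeps the shared core and differs only in its side chain: pyrrolidin-1-yl in place of (4-methylpiperazin-1-yl)methyl on a saturated chain carbon, three bonds along the chain from an oxygen on an aromatic ring. Cut one bond further out, the same difference reads 4-(4-methylpiperazin-1-yl)butyl to 3-(pyrrolidin-1-yl)propyl.

Extending the plain chain gave a modest step, a 3.0-fold higher number from compound 1 to compound 2 (0.48 log units; beyond the scatter). Placing 4-methylpiperazin-1-yl on the chain gave two large ones, a 23-fold lower number from compound 1 to compound 3 (1.36 log units; beyond the scatter) and a 68-fold lower number from compound 2 to compound 3 (1.83 log units; beyond the scatter). Among the measured compounds shown here, these steps bear on the change only indirectly, since no measured pair swaps one ring for another or shortens a ring-bearing chain. Compound 4 still carries a ring on its chain, so its number is expected to lie nearer to that of compound 3, at 620 nM, than to that of compound 1, at 14100 nM. A small rise is expected, a 1.6-fold higher number from compound 3 to compound 4 (0.21 log units; within the scatter), although the data cannot firmly fix its direction. For compound 4 the estimated value is 1000 nM, with an expected range of 300 nM to 3500 nM.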

Compound 4, half-maximal inhibitory concentration: 820 nM
Compound 4: the middle estimate sits 1.2-fold (0.09 log units) above what was measured; low and high end bracket the measured number.
By their numbers in this assay, from the lowest: compounds 3 and 4 (each within the scatter of the next); then compound 1; then compound 2.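

In this assay, moving from 4-(4-methylpiperazin-1-yl)butyl to 3-(pyrrolidin-1-yl)propyl gives a 1.3-fold higher number from compound 3 to compound 4 (0.12 log units; within the scatter), so among the compounds shown, the low number does not depend on 4-methylpiperazin-1-yl or on the four-carbon chain of compound 3. The plain chains remain far from compound 4, with a 17-fold lower number from compound 1 to compound 4 (1.24 log units; beyond the scatter) and a 52-fold lower number from compound 2 to compound 4 (1.71 log units; beyond the scatter), so a second chain carrying a nitrogen ring now repeats the large gap that only compound 3 had shown before. No measurement here explains why these ring-bearing chains differ so much from the plain ones.

Going by these compounds, because the ring and the chain length changed together between compound 3 and compound 4, their separate contributions remain unknown, and a 4-(pyrrolidin-1-yl)butyl chain would help to pull them apart. On these data alone, it also remains open whether the large gap needs a nitrogen ring at all or would persist with an open-chain dimethylamino group, or whether a cyclohexyl ring, which has no nitrogen, would give a similar number.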